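Working notes: methyl on the sulfonamide nitrogen

The source may hold more compounds than are shown below. What is called first, only, known or untested is meant among the compounds shown, and "the series" means these compounds.

- compound 1 `N#CCn1c(=N)sc2cc(OC(F)(F)F)ccc21` gives 3.5 mg/kg
- compound 2 `COC(=O)Cn1c(=N)sc2cc(OC(F)(F)F)ccc21` gives > 10 mg/kg (a limit of the assay)
- compound 3 `CNS(=O)(=O)CCn1c(=N)sc2cc(OC(F)(F)F)ccc21` gives 4 mg/kg

In a functional assay on the whole organism with Rattus norvegicus as the target (on this read-out higher numbers stand for an effect only at larger amounts of compound and lower numbers for an effect already at smaller amounts), compound 3 gives 4 mg/kg and lies within the scatter of compound 1 at 3.5 mg/kg. Compound 2 is known only as a limit of the assay, > 10 mg/kg.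

The next structure is compound 4 `CN(C)S(=O)(=O)CCn1c(=N)sc2cc(OC(F)(F)F)ccc21` with the difference (methyl in place of hydrogen on a sulfonamide nitrogen), which is methyl in place of hydrogen on a sulfonamide nitrogen.

Among the compounds with values here, no measured step changes this nitrogen. The nearest guides replace the whole group on the chain carbon. Of these, a 1.1-fold higher number from compound 1 to compound 3 (0.06 log units; within the scatter) stays within the scatter, while an at least 2.8-fold higher number from compound 1 to compound 2 (0.45 log units; beyond the scatter) and an at least 2.5-fold lower number from compound 2 to compound 3 (0.39 log units; beyond the scatter) go beyond it, and both of those involve compound 2 .

The change here is much smaller, so with compound 3 as the anchor at 4 mg/kg no shift beyond the scatter is expected. The expected step is no change at the digits printed from compound 3 to compound 4 (within the scatter). For compound 4 the estimated value is 4 mg/kg, with an expected range from 1.5 mg/kg to 10 mg/kg.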

Compound 4, dose for half-maximal effect: > 10 mg/kg
Compound 4: a limit, no number (the forecaster's own chance of this, stated with the estimate: 15%); middle value at least 2.5-fold (0.39 log units) away from the limit.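

In this assay, the sulfonamide nitrogen turns out to be a sensitive place: methyl in place of hydrogen there gives an at least 2.5-fold higher number from compound 3 to compound 4 (0.39 log units; beyond the scatter), although compound 3 had stayed within the scatter of compound 1. The same single methyl also separates compound 4 from the nitrile, with an at least 2.8-fold higher number from compound 1 to compound 4 (0.45 log units; beyond the scatter), so (dimethylsulfamoyl)methyl does not match cyano in the way (methylsulfamoyl)methyl does. Compound 4 is known only as a limit, so both steps are lower bounds and the step from compound 2 cannot be read, because both compounds sit at the end of the measured range: the limit of > 10 mg/kg in this assay, at which 2 of the 4 values shown sit.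

From the compounds shown here alone, the true size of the step remains open, as does whether it follows from the added methyl or from the lost hydrogen on that nitrogen. An unsubstituted sulfamoyl group or an ethyl on that nitrogen would help separate these two readings.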